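The compounds below may be only part of what the source reports. "The series", "measured", "known", "first", "only" and "open" are said of these compounds alone.

Compound 2, `CC(Sc1nnc(-c2ccncc2)s1)C(=O)Nc1ccccc1Cl`, is one of three close relatives built on the same shared core. In an ADME assay on HepG2 cells (Homo sapiens) for cytotoxicity, with a stated time of 3 days (on this read-out lower numbers stand for higher toxicity in this test and higher numbers for lower toxicity in this test), compound 2 gives > 50000 nM, which is a limit of the test rather than a measured number. Compound 3, `CC(Sc1nnc(-c2ccncc2)s1)C(=O)Nc1ccc(Cl)cc1`, gives > 50000 nM in this assay, again a limit. Compound 1, `CC(Sc1nnc(-c2ccncc2)s1)C(=O)NCc1ccc(Cl)cc1`, has "not determined" (no result reported) in this assay. Within the data shown here, the only measured step, a step that the two limits leave unreadable from compound 2 to compound 3, concerns a different part of the molecule and cannot be read. Compound 4, `O=C(CSc1nnc(-c2ccncc2)s1)Nc1ccccc1Cl`, differs from compound 2 by hydrogen in place of methyl on a saturated chain carbon bound to a carbonyl carbon and a sulfur. Among the measured compounds shown here, no measured step touches this change, but the limit of > 50000 nM in this assay, at which 2 of the 3 values shown sit, suggests low toxicity is the common outcome here. Compound 4 is therefore expected to give 60000 nM in this assay, within 20000 nM to 200000 nM. The step that the limit leaves unreadable from compound 2 to compound 4 is expected to lie within the scatter.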

Compound 4, half-maximal cytotoxic concentration: > 50000 nM
Compound 4 ended at the assay's limit (the forecaster's own chance of this, stated with the estimate: 85%); the middle value does not contradict the limit.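

Compound 2 and compound 4 both stand at a limit in this assay, and the step between them, hydrogen in place of methyl, cannot be read. The compounds shown leave open whether this change affects toxicity in this test at all.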